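A few compounds are considered here, and "the series" means these few. Any claim that something is new, unique, unknown or untested is made for them only; others in the source may bear on it.

Working notes on the series. In a functional assay on PANC-1 cells (Homo sapiens) for antiproliferative activity, read by CCK-8 assay, with a stated time of 72 h (a lower number here means a stronger inhibitor, a higher number a weaker inhibitor), compound 1 `COc1cccc(Nc2nc(Nc3cc(C)[nH]n3)cc(N3CCN(C)CC3)n2)c1` gives 693 nM and compound 2 `Cc1cc(Nc2cc(N3CCN(C)CC3)nc(Nc3ccc(C#N)cc3)n2)n[nH]1` gives 435 nM. Going by the values given here, these are the only two numbers so far, and compound 2 stands level with compound 1 within the scatter. The next compound is compound 3 `COc1ccc(Nc2nc(Nc3cc(C)[nH]n3)cc(N3CCN(C)CC3)n2)cc1`, with methoxy in place of cyano on an aromatic carbon, para to a large group: methoxy in place of cyano on an aromatic carbon. Among the compounds with values here, one measured step bears on this change: a 1.6-fold lower number from compound 1 to compound 2 (0.20 log units; within the scatter), with 4-cyanophenyl in place of 3-methoxyphenyl. That step replaces 3-methoxyphenyl rather than 4-methoxyphenyl, so it is only an indirect guide. Within the data shown here, with that step as the sole guide, no step beyond the scatter is expected in this assay, and no direction can be firmly expected. The estimated value for compound 3 is 600 nM, with an expected range of 250 nM to 1400 nM. The estimated step is a 1.4-fold higher number from compound 2 to compound 3 (0.14 log units; within the scatter).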

Compound 3, half-maximal inhibitory concentration: 1120 nM
Compound 3: middle estimate off by 1.9-fold (0.27 log units), on the low side; low and high end bracket the measured number.
By their numbers in this assay, from the lowest: compounds 2, 1 and 3 (each within the scatter of the next, the first and the last beyond it).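

Going by these compounds alone, on an aromatic carbon para to a large group, methoxy in place of cyano gives a 2.6-fold higher number from compound 2 to compound 3 (0.41 log units; beyond the scatter) in this assay and is a modest step, the only one beyond the scatter so far. This shows that the substituent at this position can move the number, which the earlier comparison could not show. Moving the methoxy, with 4-methoxyphenyl in place of 3-methoxyphenyl, gives a 1.6-fold higher number from compound 1 to compound 3 (0.21 log units; within the scatter) and so does not separate the two methoxyphenyl compounds. No measurement available here accounts for the step from cyano to methoxy.

On these data alone, it remains open whether the step is specific to this pair of groups or extends to others at this position, such as an amine, a carboxylic acid or a longer chain. A single pair gives no trend across substituents.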